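The compounds below may be only part of what the source reports. "The series", "measured", "known", "first", "only" and "open" are said of these compounds alone.

Measured so far in an ADME assay for permeability, using PAMPA, with a stated time of 30 min, at pH 7.4; a lower number here means that the compound crosses the layer more slowly, a higher number that the compound crosses the layer faster:
compound 1, `COc1ccc(F)cc1CNCCCNc1ccnc2cc(CCc3ccccc3)ccc12`, 23 10^-6 cm/s
compound 2, `COc1ccc(F)cc1CNCCCNc1ccnc2cc(CC(C)C)ccc12`, 23 10^-6 cm/s
compound 3, `COc1ccc(F)cc1CNCCCNc1ccnc2cc(CC3CCCCC3)ccc12`, 23 10^-6 cm/s

Compound 3 stands level with compounds 1 and 2 in this assay: the steps of no change at the digits printed from compound 1 to compound 3 (within the scatter) and no change at the digits printed from compound 2 to compound 3 (within the scatter) both fall within the scatter, as does no change at the digits printed from compound 1 to compound 2 (within the scatter). Across the three, exchanging the group on the saturated chain carbon bound to an aromatic carbon has left the read-out unmoved.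

Compound 4, `COc1ccc(F)cc1CNCCCNc1ccnc2cc(Oc3ccc(Cl)cc3)ccc12`, has not been measured in this assay. Its difference from compound 3 is 4-chlorophenoxy in place of cyclohexylmethyl on an aromatic carbon. Within the data shown here, the three measured steps are the only guide; each was within the scatter, and none of them swaps a saturated carbon group for an aryl ether on the aromatic carbon itself, so they bear on the new step only as a sign that this part of the core has so far accepted varied groups without shifting the read-out. The step of a 1.0-fold lower number from compound 3 to compound 4 (0.02 log units; within the scatter) is therefore expected to stay within the scatter, with no clear direction. Compound 4 is estimated at 22 10^-6 cm/s, in the range 11 10^-6 cm/s to 40 10^-6 cm/s.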

Compound 4, apparent permeability: 317 10^-6 cm/s
Compound 4: middle estimate off by 14-fold (1.16 log units), on the low side, and the stated range ends below it.
By their numbers in this assay, from the lowest: compounds 1, 2 and 3 (each within the scatter of the next); then compound 4.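

In this assay the position on the aromatic carbon is no longer silent: 4-chlorophenoxy in place of cyclohexylmethyl gives a 14-fold higher number from compound 3 to compound 4 (1.14 log units; beyond the scatter) and in place of isobutyl gives a 14-fold higher number from compound 2 to compound 4 (1.14 log units; beyond the scatter) while in place of phenethyl it gives a 14-fold higher number from compound 1 to compound 4 (1.14 log units; beyond the scatter) and all three steps are large. The three carbon-linked groups stand level with one another, so tolerance among saturated chains did not extend to this exchange, where a ring is joined to the aromatic carbon through oxygen and carries chlorine. Nothing measured here bears on the cause of the rise.

With one such compound, the oxygen link, the aromatic ring and the chlorine cannot be separated. Unsubstituted phenoxy and 4-chlorobenzyl at this carbon would be the direct comparisons, and how far the step holds for either remains open.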